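The compounds below may be only part of what the source reports. "The series", "measured", "known", "first", "only" and "open" are said of these compounds alone.

Measured compounds:
- compound 1, `COc1cc(/C=C/C(=O)/C=C/c2cccs2)ccc1OCc1cn(CCOc2cc(=O)oc3ccccc23)nn1`: 12% in a functional assay on PC-3 cells (Homo sapiens) for inhibition, read by sulforhodamine B assay, with a stated time of 48 h, tested at 50 uM; on this read-out higher numbers stand for more inhibition of growth at the one concentration tested and lower numbers for less inhibition of growth
- compound 2, `COc1cccc(/C=C/C(=O)/C=C/c2ccc(OCc3cn(CCCCCOc4cc(=O)oc5ccccc45)nn3)c(OC)c2)c1`: compound 2 is reported as "not active" (no number reported) in this assay, no number given
- compound 3, `COc1cccc(/C=C/C(=O)/C=C/c2ccc(OCc3cn(CCOc4cc(=O)oc5ccccc45)nn3)c(OC)c2)c1`: 13% in this assay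

Compound 3 and compound 1 share a core and differ in one place: thiophen-2-yl in place of 3-methoxyphenyl on a double-bonded chain carbon bound to a double-bonded chain carbon. The step this change makes in this assay is a number 1 percentage points lower from compound 3 to compound 1 (within the scatter), so the two are indistinguishable on this read-out. Compound 2 stands on a different core; how the core of compound 2 differs from the core of compound 3 is not broken down here. For compound 2 no number is recorded in this assay, only the report that it is not active.

Compound 4, `COc1cc(/C=C/C(=O)/C=C/c2cccs2)ccc1OCc1cn(CCCCCOc2cc(=O)oc3ccccc23)nn1`, is not yet measured. It relates to compound 2 exactly as compound 1 relates to compound 3: thiophen-2-yl in place of 3-methoxyphenyl on a double-bonded chain carbon bound to a double-bonded chain carbon, the same change at the same place. Since that change moved nothing beyond the scatter between compound 3 and compound 1, as shown by a number 1 percentage points lower from compound 3 to compound 1 (within the scatter), the expectation is that it also moves little on the core of compound 2, and compound 2 itself is reported as "not active" (no number reported). Compound 4 is therefore expected to give roughly 8% in this assay, with the plausible range estimated at 0% to 20%, and a real chance that it is again reported only as not active.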

Compound 4, percent growth inhibition at one concentration: "not active" (no number reported)
Compound 4 has no reported number here; no gap can be computed for the estimate.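

In this assay compound 2 and compound 4 are both reported only as not active, so no step can be read between them. No measured evidence accounts for this result. The compounds shown leave open whether thiophen-2-yl in place of 3-methoxyphenyl changes anything on the core of compound 2, since neither compound has a number to compare.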